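Charged side-chain variants in one bradykinin receptor series

This account rests on a few compounds, and the source may have more. Where it says the series, first, only, none or still open, it means among the compounds named here.

Compound 1, `Cc1cc(C)c2cccc(OCc3c(Cl)ccc(S(=O)(=O)NC4(C(=O)N5CCN(C(=O)[C@@H](N)CCCCN)CC5)CCCC4)c3Cl)c2n1`: in an assay on isolated protein for binding affinity to B1 bradykinin receptor (Homo sapiens) (a lower number here means a stronger inhibitor, a higher number a weaker inhibitor), compound 1 gives < 10000 nM, a limit of the assay.
Compound 2, `Cc1cc(C)c2cccc(OCc3c(Cl)ccc(S(=O)(=O)NC4(C(=O)N5CCN(C(=O)C[C@@H](N)CCCN)CC5)CCCC4)c3Cl)c2n1`: in this assay compound 2 gives < 10000 nM, again a limit.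
Compound 3, `Cc1cc(C)c2cccc(OCc3c(Cl)ccc(S(=O)(=O)NC4(C(=O)N5CCN(C(=O)CCCC[N+](C)(C)C)CC5)CCCC4)c3Cl)c2n1`: in this assay compound 3 gives < 10000 nM, also a limit.

Compound 3 thus stands at the same limit as the other two; none of the three carries a number. The steps a step that the two limits leave unreadable from compound 1 to compound 2, a step that the two limits leave unreadable from compound 1 to compound 3 and a step that the two limits leave unreadable from compound 2 to compound 3 are all unreadable, since every value sits at the limit of < 10000 nM in this assay, at which 3 of the 3 values shown sit. Compound 4, `Cc1cc(C)c2cccc(OCc3c(Cl)ccc(S(=O)(=O)NC4(C(=O)N5CCN(C(=O)[C@H](CCC[N+](C)(C)C)[N+](C)(C)C)CC5)CCCC4)c3Cl)c2n1`, differs from compound 3 by a group of 4 heavy atoms (3 carbon, 1 nitrogen; no ring) in place of a hydrogen atom, on a saturated chain carbon bound to a carbonyl carbon and a saturated chain carbon. For the measured compounds named here, no measured step resolves a change of this kind, so no direction in this assay can be read from the series. For compound 4 the estimate is 3000 nM, expected between 300 nM and 10000 nM. The step that the limit leaves unreadable from compound 3 to compound 4 that this estimate means is expected to stay within the scatter, with a limit again the most likely outcome.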

Compound 4, inhibition constant: < 10000 nM
Compound 4: no number, only a limit; the forecaster's own chance of this, stated with the estimate: 70%; the middle value does not contradict the limit.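

No new step can be read between compound 4 and compound 1, compound 2 or compound 3, because each value in this assay is a limit: the limit of < 10000 nM in this assay, at which 4 of the 4 values shown sit.

The compounds shown leave open whether any of these side-chain changes alters the inhibition constant, and by how much.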